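Quinoline biaryl nitriles: substituent variation on the pendant ring

This account rests on a few compounds, and the source may have more. Where it says the series, first, only, none or still open, it means among the compounds named here.

Measured compounds:
compound 1 `Cc1ccc2ccc(-c3cc(Br)cc(C#N)c3)cc2n1` — 13 nM
compound 2 `Cc1ccc2ccc(-c3cc(C#N)cc(OC(C)C)c3)cc2n1` — 310 nM

Both compounds were tested in a functional assay on CHO cells for inhibition of metabotropic glutamate receptor 5 (Rattus norvegicus), read by FLIPR and calcium flux; a higher number here means a weaker inhibitor, a lower number a stronger inhibitor. Compound 1 gives 13 nM and compound 2 gives 310 nM. Within this pair compound 2 stands at the higher number, as the single measured step shows: a 24-fold higher number from compound 1 to compound 2 (1.38 log units; beyond the scatter). The shared core of compound 2 is kept unchanged in compound 3 `CCS(=O)(=O)c1cc(C#N)cc(-c2ccc3ccc(C)nc3c2)c1`, which has not yet been measured in this assay.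

The change from compound 2 to compound 3 is: ethylsulfonyl in place of isopropoxy on an aromatic carbon.

Going by the values given here, only one measured step exists, and it concerns the exchange of bromo for isopropoxy, not the entry of ethylsulfonyl. That step was large, a 24-fold higher number from compound 1 to compound 2 (1.38 log units; beyond the scatter), which shows that this position is sensitive to what sits on it, but it gives no direction for the present change. The data therefore support no confident expectation of a step beyond the scatter in either direction; the estimate for compound 3 is centred on the value of compound 2 with a wide range, expected as 300 nM, between 60 nM and 1500 nM, which corresponds to an expected step of a 1.0-fold lower number from compound 2 to compound 3 (0.01 log units; within the scatter).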

Compound 3, half-maximal inhibitory concentration: 1090 nM
Compound 3: the middle estimate sits 3.6-fold (0.56 log units) below what was measured, and the stated range covers the measured number.
By their numbers in this assay, from the lowest: compound 1; then compound 2; then compound 3.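

Notes on the position meta to a cyano group: in this assay, the exchange of isopropoxy for ethylsulfonyl gives a 3.5-fold higher number from compound 2 to compound 3 (0.55 log units; beyond the scatter) and takes the series further from the bromo result, so the first loss at this position was not the limit of what a change here can cost. Measured against bromo directly, ethylsulfonyl gives an 84-fold higher number from compound 1 to compound 3 (1.92 log units; beyond the scatter), a larger step than the one seen with isopropoxy, and the three groups now stand in a clear order from the lowest number: bromo, then isopropoxy, then ethylsulfonyl, with each step between them beyond the scatter. No measurement of any property of these groups is at hand to account for that order.

Three groups on one carbon of one shared core cannot show whether the low number of compound 1 is particular to bromo or is shared by chloro, a methyl group or a second nitrile. As far as these compounds go, how an amine, a carboxylic acid or a longer alkyl sulfonyl chain would stand on this same carbon also remains open.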